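Cyclopropyl for butyl on the double-bonded nitrogen

The source may hold more compounds than are shown below. What is called first, only, known or untested is meant among the compounds shown, and "the series" means these compounds.

Going by the values given here, compound 3 `CCCC/N=C(\S)OC[C@H]1OC(n2cnc3c(NC4CCOC4)ncnc32)[C@H](O)[C@@H]1O` gives 157 nM in an assay on DDT1 cells (Cricetulus griseus) for binding affinity to adenosine receptor A1 (Homo sapiens), read by radioligand binding (a higher number here means a weaker inhibitor, a lower number a stronger inhibitor), the second highest of the three numbers so far. Compound 1 `CC/N=C(\S)OC[C@H]1OC(n2cnc3c(NC4CCOC4)ncnc32)[C@H](O)[C@@H]1O` gives 33 nM in this assay, and compound 2 `CCCCNC(=O)OC[C@H]1OC(n2cnc3c(NC4CCOC4)ncnc32)[C@H](O)[C@@H]1O` gives 1410 nM; the measured steps are a 4.8-fold higher number from compound 1 to compound 3 (0.68 log units; beyond the scatter), a 43-fold higher number from compound 1 to compound 2 (1.63 log units; beyond the scatter) and a 9.0-fold lower number from compound 2 to compound 3 (0.95 log units; beyond the scatter). Compound 4 `O[C@@H]1[C@@H](CO/C(S)=N/C2CC2)OC(n2cnc3c(NC4CCOC4)ncnc32)[C@@H]1O` differs from compound 3 by cyclopropyl in place of butyl on a double-bonded nitrogen. The step that bears most directly on this change is a 4.8-fold higher number from compound 1 to compound 3 (0.68 log units; beyond the scatter), where the shorter substituent on that chain went with the lower number; the steps involving compound 2 concern the sulfur-for-oxygen exchange instead. A modest downward step beyond the scatter is therefore expected for a 2.6-fold lower number from compound 3 to compound 4 (0.42 log units; beyond the scatter). For compound 4 the estimated value in this assay is 60 nM, with a range from 20 nM to 200 nM.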

Compound 4, inhibition constant: 157 nM
Compound 4: the middle estimate sits 2.6-fold (0.42 log units) below what was measured; low and high end bracket the measured number.
By their numbers in this assay, from the lowest: compound 1; then compounds 3 and 4 (each within the scatter of the next); then compound 2.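

On the double-bonded nitrogen, this assay does not separate cyclopropyl from butyl (no change at the digits printed from compound 3 to compound 4 (within the scatter)). The ring does not match ethyl at this place (a 4.8-fold higher number from compound 1 to compound 4 (0.68 log units; beyond the scatter)), while the distance from the oxygen-bearing compound remains (a 9.0-fold lower number from compound 2 to compound 4 (0.95 log units; beyond the scatter)), so ethyl alone stands apart among these three substituents. Nothing available explains this pattern.

From the compounds shown here alone, whether the ethyl result reflects chain length alone remains open. Propyl, a longer chain such as hexyl, or a cyclobutyl ring on that nitrogen could test this.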